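Extending the alkyl chain on the triazole of compound 3

A few compounds are considered here, and "the series" means these few. Any claim that something is new, unique, unknown or untested is made for them only; others in the source may bear on it.

For the measured compounds named here, compound 1 `O=c1cc(Cn2cc(CCCCl)nn2)c2ccc(O)cc2o1` is the only member of the set with a number rather than a limit: in a functional assay on CFPAC-1 cells (Homo sapiens) for inhibition, read by MTT assay, with a stated time of 72 h (a higher number here means a weaker inhibitor, a lower number a stronger inhibitor), compound 1 gives 75800 nM. Compound 2 `CC(C)(C)c1cn(Cc2cc(=O)oc3cc(O)ccc23)nn1` gives > 100000 nM, which is a limit of the assay. Compound 3 `CCCCCCc1cn(Cc2cc(=O)oc3cc(O)ccc23)nn1` gives > 100000 nM, again a limit of the assay. Compound 3 thus sits at the limit of > 100000 nM in this assay, at which 2 of the 3 values shown sit. Compound 4 `CCCCCCCCc1cn(Cc2cc(=O)oc3cc(O)ccc23)nn1` has not been measured; it differs from compound 3 by ethyl in place of hydrogen on a saturated chain carbon, six bonds along the chain from an aromatic carbon. The step bearing most closely on this change is an at least 1.3-fold higher number from compound 1 to compound 3 (0.12 log units; that floor lies within the scatter), where a longer chain replaced a chloro and the number moved up to the limit; the step that the two limits leave unreadable from compound 2 to compound 3 gives no readable size. Neither step shows a gain from a longer chain, so no move to a lower number beyond the scatter is expected in this assay, and a step that the limit leaves unreadable from compound 3 to compound 4 is expected, most likely ending once more at a limit. Compound 4 is therefore estimated at 150000 nM, with a range from 60000 nM to 400000 nM.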

Compound 4, half-maximal inhibitory concentration: 62700 nM
Estimate against measurement, compound 4: 2.4-fold (0.38 log units) above; the range from low to high includes it.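

In this assay the octyl chain of compound 4 gives a number where the hexyl chain of compound 3 and the tert-butyl group of compound 2 give only limits of the assay: the limit of > 100000 nM in this assay, at which 2 of the 4 values shown sit. Ethyl in place of hydrogen at this chain carbon gives an at least 1.5-fold lower number from compound 3 to compound 4 (0.20 log units; that floor lies within the scatter), and the comparison with the tert-butyl group gives an at least 1.5-fold lower number from compound 2 to compound 4 (0.20 log units; that floor lies within the scatter), so neither floor yet shows a real gain from the longer chain. The comparison with the 3-chloropropyl chain gives a 1.2-fold lower number from compound 1 to compound 4 (0.08 log units; within the scatter), which leaves compound 4 and compound 1 indistinguishable in this read-out.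

On these data alone, whether a longer chain than octyl would move the number beyond the scatter remains open. So does the effect of a terminal amine or carboxylic acid on the chain.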